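Aryl variation on the fused core: indolyl replacement

The source may hold more compounds than are shown below. What is called first, only, known or untested is meant among the compounds shown, and "the series" means these compounds.

Compound 1 `COc1cc(-c2ccnc3cc(-c4ccc(C)cc4)nn23)cc(OC)c1OC` carries a 4-methylphenyl group and in a functional assay on A549 cells (Homo sapiens) for inhibition, read by CCK-8 assay, with a stated time of 48 h (on this read-out higher numbers stand for weaker inhibition and lower numbers for stronger inhibition), compound 1 gives 3 nM, the lowest number of the three measured. Compound 2 `COc1cc(-c2ccnc3cc(-c4ccc(C(C)=O)cc4)nn23)cc(OC)c1OC` gives 4100 nM in this assay, and compound 3 `COc1ccc(-c2cc3nccc(-c4cc(OC)c(OC)c(OC)c4)n3n2)cc1F` gives 545 nM. Compound 3 thus stands second highest of the three: a 7.5-fold lower number from compound 2 to compound 3 (0.88 log units; beyond the scatter), whereas a 180-fold higher number from compound 1 to compound 3 (2.26 log units; beyond the scatter).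

Compound 4 `COc1cc(-c2ccnc3cc(-c4ccc5ccn(C)c5c4)nn23)cc(OC)c1OC` differs from compound 3 only at the aryl group on the core: 1-methyl-1H-indol-6-yl in place of 3-fluoro-4-methoxyphenyl on an aromatic carbon.

Every measured step changes this same aryl group on the same aromatic carbon, and each has been large or modest: a 1400-fold higher number from compound 1 to compound 2 (3.14 log units; beyond the scatter), a 180-fold higher number from compound 1 to compound 3 (2.26 log units; beyond the scatter), a 7.5-fold lower number from compound 2 to compound 3 (0.88 log units; beyond the scatter). For the measured compounds named here, no measured pair contains a two-ring group at this position, so there is no direct precedent, and the direction of the step to compound 4 is uncertain; the spread seen so far says only that the position is sensitive.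

Compound 4 is expected to give about 150 nM in this assay, within 15 nM to 1500 nM. The implied step, a 3.6-fold lower number from compound 3 to compound 4 (0.56 log units; beyond the scatter), is estimated to be modest and could fall on either side of the scatter.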

Compound 4, half-maximal inhibitory concentration: 829 nM
Compound 4: middle estimate off by 5.5-fold (0.74 log units), on the low side; measured number inside the range.
By their numbers in this assay, from the lowest: compound 1; then compounds 3 and 4 (each within the scatter of the next); then compound 2.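

In this assay, for the compounds shown here, the two-ring 1-methyl-1H-indol-6-yl group and the one-ring 3-fluoro-4-methoxyphenyl group cannot be told apart (a 1.5-fold higher number from compound 3 to compound 4 (0.18 log units; within the scatter)), the first step at this aromatic carbon to stay within the scatter. The step from 4-methylphenyl remains large (a 280-fold higher number from compound 1 to compound 4 (2.44 log units; beyond the scatter)) and the step from 4-acetylphenyl modest (a 4.9-fold lower number from compound 2 to compound 4 (0.69 log units; beyond the scatter)), so a second fused ring at this position neither matches compound 1 nor reads as high as compound 2. Nothing available explains these differences.

Still open, from the compounds shown here alone, is how far the low number of compound 1 depends on the methyl group, which a 4-ethylphenyl or 4-aminophenyl group at this position would help to test. Also open, going by these compounds, is whether an indolyl group lacking its methyl, or joined through another ring carbon, would read the same as compound 4.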